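Swapping 2-chlorophenyl for pyridin-3-yl in compound 3

The source may hold more compounds than are shown below. What is called first, only, known or untested is meant among the compounds shown, and "the series" means these compounds.

In a functional assay on HeLa cells (Homo sapiens) for cytotoxicity, read by ELISA, with a stated time of 4 days (on this read-out lower numbers stand for stronger inhibition and higher numbers for weaker inhibition), compound 1 (`Clc1ccc(-c2cc(-c3ccco3)cc(-c3ccc(Cl)s3)n2)cc1`) gives 17000 nM, compound 2 (`Clc1ccc(-c2cc(-c3ccoc3)cc(-c3ccco3)n2)s1`) gives 22700 nM and compound 3 (`Clc1ccc(-c2cc(-c3ccoc3)cc(-c3ccccc3Cl)n2)s1`) gives 19000 nM. Compound 3 therefore lies within the usual scatter of both others. Compound 4 (`Clc1ccc(-c2cc(-c3ccoc3)cc(-c3cccnc3)n2)s1`) carries pyridin-3-yl in place of 2-chlorophenyl on an aromatic carbon. Among the measured compounds shown here, the one measured step at that carbon, a 1.2-fold lower number from compound 2 to compound 3 (0.08 log units; within the scatter), brought in the 2-chlorophenyl group and stayed within the scatter. For the measured compounds named here, no measured compound carries pyridin-3-yl, so this evidence is thin. No step beyond the scatter is expected in this assay, and no direction can be favoured. The expected change is small, a 1.1-fold higher number from compound 3 to compound 4 (0.02 log units; within the scatter). For compound 4 the estimate is 20000 nM, with an expected range of 10000 nM to 40000 nM.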

Compound 4, half-maximal inhibitory concentration: 20000 nM
Compound 4: middle estimate and measured number agree at the digits printed; the range from low to high includes it.
By their numbers in this assay, from the lowest: compounds 1, 3, 4 and 2 (each within the scatter of the next).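

In this assay, placing pyridin-3-yl at this carbon next to the ring nitrogen gives a 1.1-fold higher number from compound 3 to compound 4 (0.02 log units; within the scatter) and a 1.1-fold lower number from compound 2 to compound 4 (0.05 log units; within the scatter), so a ring with 1 hydrogen-bond acceptor reads the same, within the scatter, as 2-chlorophenyl and furan-2-yl. Three quite different aromatic rings at this carbon therefore give no separation in this assay. Nothing available explains this. Still open, as far as these compounds go, is whether a group that is not an aromatic ring, such as an amine or a carboxylic acid, would move the number beyond the scatter at this carbon.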